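The compounds below may be only part of what the source reports. "The series", "measured", "known", "first", "only" and "open" are said of these compounds alone.

Compound 1 has the structure `COc1cc(C(=O)/C=C/c2ccc(OCCCC(=O)NCCCNCCCCN)cc2)cc(OC)c1OC`: a polyamine tail fixed through an amide to the shared core. In a functional assay on PC-3 cells (Homo sapiens) for antiproliferative activity, read by MTT assay, with a stated time of 48 h (on this read-out lower numbers stand for stronger inhibition and higher numbers for weaker inhibition), compound 1 gives > 100000 nM, and this figure is a limit of the assay rather than a measured number, the point described as the limit of > 100000 nM in this assay, at which 1 of the 2 values shown sits. Compound 1 therefore stands at the weak end of what this assay can register. Compound 2, with the structure `COc1ccc(/C=C/C(=O)c2cc(OC)c(OC)c(OC)c2)cc1OCCCC(=O)NCCCCN(CCCN)CCCCNCCCN`, carries a longer amine chain on the same core; in this assay compound 2 gives 48100 nM. Among the measured compounds shown here, these two differ in more than one place, so no single step joins them.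

Compound 3, `COc1cc(C(=O)/C=C/c2ccc(OCCCC(=O)NCCCCNCCCN)cc2)cc(OC)c1OC`, has the same atoms as compound 1 joined differently: ((3-aminopropyl)amino)methyl in place of (4-aminobutyl)amino on a saturated chain carbon, three bonds along the chain from an amide-type nitrogen. The tail keeps its parts but rearranges their order along the chain. Such a rearrangement is expected to leave the activity about where it was, so the step of a number no higher from compound 1 to compound 3 (the limit leaves the size open) is expected to stay within the usual scatter, with no clear direction. Compound 3 is therefore expected to give 100000 nM in this assay, within a range from 30000 nM to 300000 nM, and it may well again return only a limit.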

Compound 3, half-maximal inhibitory concentration: 79300 nM
Estimate against measurement, compound 3: 1.3-fold (0.10 log units) above, within the range that was stated.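

Among the compounds shown here, compound 1 and compound 3 form the first pair here that differs in one place, so the order of the parts along the tail can now be looked at on its own: ((3-aminopropyl)amino)methyl in place of (4-aminobutyl)amino, on a saturated chain carbon, three bonds along the chain from an amide-type nitrogen. With the same atoms in the new order, compound 3 gives a true number in this assay, 79300 nM, and the change reads as an at least 1.2-fold lower number from compound 1 to compound 3 (0.10 log units; that floor lies within the scatter). The value of compound 1 is a limit and not a number, so this step has only a floor, which leaves the real size of the change unknown: the limit of > 100000 nM in this assay, at which 1 of the 3 values shown sits.

Going by these compounds, what stays open is whether the order of the parts along the tail matters at all in this assay, since the floor cannot separate a real change from none. Also open, on these data alone, is how this position would respond to a different tail, such as a single 3-aminopropyl group or a chain ending in a carboxylic acid instead of an amine.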